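The source may report more compounds than this note shows. Statements on the series, on what has been measured and on what is new or still open speak of the compounds shown alone.

Series notes. In an ADME assay on microsomes from liver (Rattus norvegicus) for metabolic stability, with a stated time of 10 min (on this read-out lower numbers stand for a less stable compound and higher numbers for a more stable compound), compound 1 `CC(C)NCCS(=O)(=O)NC(=O)c1ccc(Nc2nc(NC3(c4ccc(Cl)cc4)CC3)nc(OCC(F)(F)F)n2)cc1` gives 100%. Compound 2 `CC(C)(C)NC(=O)NCCS(=O)(=O)NC(=O)c1ccc(Nc2nc(NC3(c4ccc(Cl)cc4)CC3)nc(OCC(F)(F)F)n2)cc1` gives 93% in this assay, and compound 3 `CC(C)NC(=O)NCCS(=O)(=O)NC(=O)c1ccc(Nc2nc(NC3(c4ccc(Cl)cc4)CC3)nc(OCC(F)(F)F)n2)cc1` gives 97%. Compound 1 holds the highest of the three readings, yet the step of a number 3 percentage points lower from compound 1 to compound 3 (within the scatter) and the step of a number 7 percentage points lower from compound 1 to compound 2 (within the scatter) both lie within the scatter, so the three compounds are not separated on this read-out.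

Compound 4 `CNC(=O)NCCS(=O)(=O)NC(=O)c1ccc(Nc2nc(NC3(c4ccc(Cl)cc4)CC3)nc(OCC(F)(F)F)n2)cc1` is not yet measured. Its change from compound 1 is methylcarbamoyl in place of isopropyl on an amine nitrogen. The two steps that bear on it, a number 7 percentage points lower from compound 1 to compound 2 (within the scatter) and a number 3 percentage points lower from compound 1 to compound 3 (within the scatter), each trade the isopropyl for a carbamoyl group on the same amine nitrogen and neither moved beyond the scatter. Compound 4 is therefore expected to show a number 4 percentage points lower from compound 1 to compound 4 (within the scatter), no step beyond the scatter. The estimate for compound 4 is 96%, within 85% to 100%.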

Compound 4, percent of the compound remaining: 100%
Estimate against measurement, compound 4: 4 percentage points below; the measured number falls inside the stated range.
By their numbers in this assay, from the lowest: compounds 2, 3, 1 and 4 (each within the scatter of the next).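

Methylcarbamoyl in place of isopropyl on the amine nitrogen gives no change at the digits printed from compound 1 to compound 4 (within the scatter) in this assay, so a third carbamoyl group also stays unseparated from compound 1. On the amide-type nitrogen, methyl in place of isopropyl gives a number 3 percentage points higher from compound 3 to compound 4 (within the scatter) and methyl in place of tert-butyl gives a number 7 percentage points higher from compound 2 to compound 4 (within the scatter), so methyl, isopropyl and tert-butyl are not separated at that place. No measurement at hand explains this flat picture.

Open, going by these compounds, is whether an acetyl group, a carboxylic acid or a longer chain on the amine nitrogen would read the same.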